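The source may hold more compounds than are shown below. What is called first, only, known or untested is meant among the compounds shown, and "the series" means these compounds.

Measured compounds:
compound 1, `Cc1cc(C)c(-c2cn(C)cn2)cc1NC(=O)c1ccc(OCc2ccccn2)cc1`, 3
compound 2, `Cc1cc(F)c(-c2ncc[nH]2)cc1NC(=O)c1ccc(OCc2ccccn2)cc1`, 3

Both measured compounds were characterised in a physicochemical assay for lipophilicity; a higher number here means a more lipophilic compound, a lower number a more polar compound. In this assay compound 1 gives 3, and in this assay compound 2 gives 3; at the digits shown these two values sit level with each other, inside the usual scatter, so nothing separates them. Compound 3, `Cc1cc(C)c(-c2c(C)nn(C)c2C)cc1NC(=O)c1ccc(OCc2ccccn2)cc1`, has not yet been measured. It differs from compound 1 in one place: 1,3,5-trimethyl-1H-pyrazol-4-yl in place of 1-methyl-1H-imidazol-4-yl on an aromatic carbon. Among the compounds with values here, no measured pair shows a change of this kind, so there is no measured step to lean on, and the expectation rests on the structural change alone. A modest step upward in this assay is expected, somewhat beyond the scatter but not large. The estimated step is a number 0.50 log units higher from compound 1 to compound 3 (beyond the scatter). Compound 3 is therefore expected to give 3.5 in this assay, with an estimated range from 3 to 4.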

Compound 3, distribution coefficient: > 3
Compound 3 was reported as a limit; the forecaster's own chance of this, stated with the estimate: 5%; the middle value does not contradict the limit.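

In this assay, compound 3 is reported as > 3, which is a limit and not a number. At this position, on an aromatic carbon ortho to a methyl group, putting 1,3,5-trimethyl-1H-pyrazol-4-yl in place of 1-methyl-1H-imidazol-4-yl gives a number no lower from compound 1 to compound 3 (the limit leaves the size open), so the change from one five-membered aromatic ring to the other, larger group does not bring the reading down. This first look at a change at this position rests on the limit alone: the limit of > 3 in this assay, at which 1 of the 3 values shown sits.

From the compounds shown here alone, the true size of the step stays open, as does the question of whether the ring swap or the added methyl groups account for it. The compounds shown also leave open how the reading would respond at this position to an amine or a carboxylic acid.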